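The source may report more compounds than this note shows. Statements on the series, on what has been measured and on what is new or still open speak of the compounds shown alone.

Compound 1 `Cc1cc(C)c(-c2nc(CN3CCC(C(=O)NCCCN4C[C@H](C)C[C@H](C)C4)CC3)c(C)o2)c(C)c1`: 6570 nM
Compound 2 `Cc1ccccc1-c1nc(CN2CCC(C(=O)NCCCN3CC(C)(C)CC(C)(C)C3)CC2)c(C)o1`: 4380 nM
Compound 3 `Cc1cccc(Cl)c1-c1nc(CN2CCC(C(=O)NCCCN3CCC(C(C)C)CC3)CC2)c(C)o1`: 4910 nM

These three numbers come from an ADME assay on Huh7.5.1 cells (Homo sapiens) for cytotoxicity, read by ATP content, with a stated time of 48 h; on this read-out higher numbers stand for lower toxicity in this test and lower numbers for higher toxicity in this test. Among them compound 1 has the highest number, but its gap to compound 3 and its gap to compound 2 both lie within the usual scatter of repeated measurements, so the three compounds cannot be told apart on this test. Compound 4 `COc1cccc(Br)c1-c1nc(CN2CCC(C(=O)NCCCN3C[C@H](C)C[C@H](C)C3)CC2)c(C)o1` has not yet been measured. It differs from compound 1 in one place: 2-bromo-6-methoxyphenyl in place of 2,4,6-trimethylphenyl on an aromatic carbon. Going by the values given here, no pair of measured compounds differs in this way, so there is no direct comparison for this change. The measured compounds carry different groups at the same place on the shared core, and compound 2 with 4380 nM and compound 3 with 4910 nM sit within the scatter of compound 1, which speaks for a small step. For compound 4 the step of a 1.2-fold lower number from compound 1 to compound 4 (0.08 log units; within the scatter) in this assay is therefore expected to stay within the scatter. Compound 4 is estimated at 5500 nM, with a range from 2500 nM to 12000 nM.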

Compound 4, half-maximal cytotoxic concentration: 14900 nM
Estimate against measurement, compound 4: 2.7-fold (0.43 log units) below; measured number outside the range, above it.
By their numbers in this assay, from the lowest: compounds 2, 3 and 1 (each within the scatter of the next); then compound 4.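

In this assay the group on the aromatic carbon of the five-membered ring can move the read-out: 2-bromo-6-methoxyphenyl in place of 2,4,6-trimethylphenyl gives a 2.3-fold higher number from compound 1 to compound 4 (0.36 log units; beyond the scatter), which points to lower toxicity in this test. The three earlier compounds differ from one another in more than one place and offered no such one-place comparison. The swap leaves the count of 9 heavy atoms unchanged and adds one hydrogen-bond acceptor, but no measurement shown here explains the higher number.

From the compounds shown here alone, the bromine and the methoxy group enter together, so their separate contributions remain open, and a simpler group such as 2-methoxyphenyl or 2-bromophenyl would address that question. Whether the same change gives a similar step with the amine ends of compound 2 or compound 3 is also unknown.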